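Fluoro in Place of Chloro: Expected Effect on Inhibition

The source may report more compounds than this note shows. Statements on the series, on what has been measured and on what is new or still open speak of the compounds shown alone.

Compound 1 `Fc1ccc(Cn2cc(CSC(=S)N3CCNCC3)nn2)cc1`: 49900 nM
Compound 2 `O=C(OCc1ccccc1)N1CCN(C(=S)SCc2cn(Cc3ccccc3F)nn2)CC1`: 7950 nM
Compound 3 `S=C(SCc1cn(Cc2ccccc2Cl)nn1)N1CCNCC1`: 38900 nM

In a functional assay on MCF7 cells (Homo sapiens) for inhibition, read by MTT assay, with a stated time of 72 h (on this read-out higher numbers stand for weaker inhibition and lower numbers for stronger inhibition), compound 3 gives 38900 nM, the second highest of the three numbers. Its nearest neighbour is compound 1, and the change a 1.3-fold lower number from compound 1 to compound 3 (0.11 log units; within the scatter) is within the scatter. Compound 2, which carries a benzyloxycarbonyl group where compounds 1 and 3 have a free ring nitrogen, is the furthest away, its number being lower than that of compound 3 by a margin beyond the scatter.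

Compound 4 `Fc1ccccc1Cn1cc(CSC(=S)N2CCNCC2)nn1` differs from compound 3 by fluoro in place of chloro on an aromatic carbon. Within the data shown here, the only measured step that bears on a halogen change is a 1.3-fold lower number from compound 1 to compound 3 (0.11 log units; within the scatter), which stayed within the scatter although it also moved the halogen around the ring. Among the measured compounds shown here, no step isolates fluoro against chloro at the same position. The step is therefore expected to be a 1.1-fold higher number from compound 3 to compound 4 (0.03 log units; within the scatter), none beyond the scatter. In this assay compound 4 is estimated at 42000 nM, with a range from 18000 nM to 100000 nM.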

Compound 4, half-maximal inhibitory concentration: 33200 nM
Compound 4: middle estimate off by 1.3-fold (0.10 log units), on the high side, and the stated range covers the measured number.
By their numbers in this assay, from the lowest: compound 2; then compounds 4, 3 and 1 (each within the scatter of the next).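

In this assay, fluoro in place of chloro on an aromatic carbon, ortho to a large group, can now be read on its own (a 1.2-fold lower number from compound 3 to compound 4 (0.07 log units; within the scatter)), and this halogen change stays within the scatter. Compound 4 also separates the place of the fluoro from the identity of the halogen: 2-fluorophenyl in place of 4-fluorophenyl gives a step within the scatter (a 1.5-fold lower number from compound 1 to compound 4 (0.18 log units; within the scatter)). Hydrogen in place of benzyloxycarbonyl on the amine nitrogen in a ring, now seen as a change in one place, gives a step beyond the scatter (a 4.2-fold higher number from compound 2 to compound 4 (0.62 log units; beyond the scatter)), so among these single changes only the one at that nitrogen exceeds the scatter.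

Going by these compounds, whether bromo or methoxy on this aromatic carbon, or acetyl or a longer chain on that nitrogen, would give similar numbers remains open. No measurement at hand explains any of these steps.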